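The source may report more compounds than this note shows. Statements on the series, on what has been measured and on what is new or still open speak of the compounds shown alone.

In a physicochemical assay for lipophilicity, read by HPLC, measured as chromatographic lipophilicity, at pH 7.4 (on this read-out lower numbers stand for lower lipophilicity and higher numbers for higher lipophilicity), compound 1 `CC(C)C(=O)N1N=CCC1c1ccccc1` reads 4.4 and compound 2 `CC(C)(CO)C(=O)N1N=CCC1c1ccccc1` reads 3.4 while compound 3 `O=C(c1ccccc1)N1N=CCC1c1ccccc1` reads 4.6 on the same scale. Phenyl in place of isopropyl gave a number 0.20 log units higher from compound 1 to compound 3 (within the scatter) and so those two cannot be told apart, whereas a number 1.20 log units higher from compound 2 to compound 3 (beyond the scatter) marks a clear gap. Compound 4 `O=C(c1ccncc1)N1N=CCC1c1ccccc1` has pyridin-4-yl in place of phenyl on a carbonyl carbon. Within the data shown here, no measured step makes this exact swap. The nearest guide is hydroxymethyl in place of hydrogen, another change that brings in a hetero atom, which gave a number 1.00 log units lower from compound 1 to compound 2 (beyond the scatter) for that pair. A downward step of similar size is therefore expected in this assay and the estimate is a number 1.10 log units lower from compound 3 to compound 4 (beyond the scatter) here. For compound 4 the estimated value is 3.5 (expected range 3 to 4).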

Compound 4, distribution coefficient: 2.7
For compound 4 the middle estimate is 0.80 log units above the measured one; measured number outside the range, below it.
By their numbers in this assay, from the lowest: compound 4; then compound 2; then compounds 1 and 3 (each within the scatter of the next).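

In this assay, pyridin-4-yl in place of phenyl on this carbonyl carbon keeps the heavy-atom count the same, yet it gives a number 1.90 log units lower from compound 3 to compound 4 (beyond the scatter) and is the largest step seen so far. Pyridin-4-yl also gives a number 0.70 log units lower from compound 2 to compound 4 (beyond the scatter) and a number 1.70 log units lower from compound 1 to compound 4 (beyond the scatter), which leaves compound 4 with the lowest number of the four. Nothing shown gives a reason for this drop. Still open, going by these compounds, is how pyridin-3-yl or pyridin-2-yl would read at this carbonyl carbon. On these data alone, whether the step would hold with a methyl group on the pyridine ring is also open.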